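Fluoro for methoxy on a quinoline sulfone: clearance expectation

The compounds below may be only part of what the source reports. "The series", "measured", "known", "first", "only" and "open" are said of these compounds alone.

The measured compounds and their values:
compound 1, `Cc1ccc(S(=O)(=O)c2cnc3cc(F)ccc3c2-c2ccc(F)cc2)cc1C`: 9.25 mL/min
compound 2, `COc1ccc(-c2c(S(=O)(=O)c3ccc(C)c(C)c3)cnc3cc(F)ccc23)cc1`: 4.13 mL/min
compound 3, `COc1ccc(-c2c(S(=O)(=O)c3cccc(F)c3)cnc3c(F)cccc23)cc1`: 2.48 mL/min

Of the compounds shown here, three have been tested in an ADME assay on microsomes from liver (Homo sapiens) for metabolic stability, tested at 2.5 uM; a lower number here means slower removal, a higher number faster removal of the compound. In this assay compound 2 gives 4.13 mL/min, while compound 1, which carries fluoro in place of methoxy on an aromatic carbon, gives 9.25 mL/min. That single change made a 2.2-fold higher number from compound 2 to compound 1 (0.35 log units; beyond the scatter). Compound 3 gives 2.48 mL/min in this assay, and its value and that of compound 2 lie within the usual scatter of each other, so no order between them is claimed. The difference between the core of compound 3 and the core of compound 2 is not broken down here.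

Compound 4, `O=S(=O)(c1cccc(F)c1)c1cnc2c(F)cccc2c1-c1ccc(F)cc1`, has not yet been measured. Going by the values given here, its relation to compound 3 is fluoro in place of methoxy on an aromatic carbon, the same change as the one from compound 2 to compound 1, at the same place on the ring. On that precedent, a step of similar size is expected from compound 3 to compound 4, namely a 2.1-fold higher number from compound 3 to compound 4 (0.32 log units; beyond the scatter), because the earlier change made a 2.2-fold higher number from compound 2 to compound 1 (0.35 log units; beyond the scatter). The expectation rests on one pair only, and the cores of compound 3 and compound 2 differ in ways not broken down here, so the range is kept wide. Compound 4 is therefore estimated at 5.2 mL/min in this assay, between 2.6 mL/min and 10.5 mL/min.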

Compound 4, intrinsic clearance in a liver preparation (reported as CLH), per the amount of preparation that the assay uses: 0.19 mL/min
The estimate for compound 4 lay 27-fold (1.44 log units) above the measured number; measured number below the stated range.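

In this assay, the change from 4-methoxyphenyl to 4-fluorophenyl gave a 13-fold lower number from compound 3 to compound 4 (1.12 log units; beyond the scatter), whereas the same change on the other core went the opposite way: the same change on two cores in this assay, a 2.2-fold higher number (0.35 log units; beyond the scatter) from compound 2 to compound 1 and a 13-fold lower number (1.12 log units; beyond the scatter) from compound 3 to compound 4, 29-fold (1.47 log units) apart, beyond the scatter of two such steps. This pair of steps shows that, in these compounds, the change cannot be carried from one core to the other, in either size or direction, and that the step measured on one core gave no safe guide to the step on the other. It does not show which of the differences between the two cores decides the outcome or why the steps part, and two pairs are too few to establish a rule for any further core in the series.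

The compounds shown leave open how a core carrying only some of these differences would respond to the same change, which could help locate the part of the core on which the outcome depends. They also leave open what a chloro group, a nitrile or an amine would give in place of the fluoro on this aromatic carbon, on either core.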